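Cinnamyl in place of methoxybenzyl on the purine nitrogen

The compounds below may be only part of what the source reports. "The series", "measured", "known", "first", "only" and "open" are said of these compounds alone.

The three measured compounds share a core and are tested in a functional assay on the whole organism with Mus musculus as the target; on this read-out higher numbers stand for larger maximal responses and lower numbers for smaller maximal responses. Compound 1 `C=CCn1c(=O)n(CCCCO)c2nc(N)nc(O)c21` gives 16%. Compound 2 `COc1ccc(Cn2c(=O)n(C3OC(CO)[C@@H](O)[C@H]3O)c3nc(N)nc(O)c32)cc1` gives 14%, and compound 3 `CCCn1c(=O)n(C2C=CC(CO)O2)c2nc(N)nc(O)c21` gives 84%. On these numbers compound 2 sits at the low end of the set: its value and that of compound 1 lie within the scatter of each other, so no order between them can be claimed, while compound 3 stands far beyond the scatter above both. Among the measured compounds shown here, no pair of measured compounds differs in one place only, so no single step is known.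

Compound 4 `Nc1nc(O)c2c(n1)n(C1OC(CO)[C@@H](O)[C@H]1O)c(=O)n2C/C=C/c1ccccc1` has not yet been measured in this assay. It differs from compound 2 in one place: 2-phenylethenyl in place of 4-methoxyphenyl on a saturated chain carbon bound to an aromatic nitrogen. The sugar and the rest of the core are unchanged. For the measured compounds named here, nothing among the measured compounds isolates the effect of this change; compound 3, the only high responder, carries a different sugar as well as a different chain on that nitrogen, and compound 1 carries an allyl group with a different chain again. The step is therefore expected to be small, most likely upward but possibly not beyond the scatter. Compound 4 is expected to give about 25%, within 8% to 55%, meaning a step of a number 11 percentage points higher from compound 2 to compound 4 (beyond the scatter).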

Compound 4, largest response reached (reported as maximal response), in percent of the reference or control that the assay uses: 5%
For compound 4 the middle estimate is 20 percentage points above the measured one; measured number outside the range, below it.
By their numbers in this assay, from the lowest: compounds 4, 2 and 1 (each within the scatter of the next, the first and the last beyond it); then compound 3.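

In this assay, among the compounds shown here, the first single-place step on this saturated chain carbon bound to an aromatic nitrogen, 2-phenylethenyl in place of 4-methoxyphenyl, gives a number 9 percentage points lower from compound 2 to compound 4 (within the scatter). This shows that, with the sugar and the rest of the core held constant, exchanging one aromatic group of 8 heavy atoms for another of the same size does not shift the maximal response beyond the scatter, even though the ether oxygen and its hydrogen-bond acceptor leave and a double bond outside the ring enters, so this pair gives no sign that the position responds to this particular change. No measurement shown here accounts for this outcome.

The compounds shown leave open whether a group of a different kind on this chain carbon, such as a primary amine, a carboxylic acid or a longer saturated alkyl chain, would move the response beyond the scatter. They also leave open whether the same 2-phenylethenyl for 4-methoxyphenyl exchange would give a similar step on a core carrying a different sugar, since every other measured compound differs from this pair in more than one place.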